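The source may hold more compounds than are shown below. What is called first, only, known or untested is meant among the compounds shown, and "the series" means these compounds.

Series on a shared core carrying a (2-hydroxyethoxy)methyl group, tested in a functional assay (Oryctolagus cuniculus) for inhibition; a higher number here means a weaker inhibitor, a lower number a stronger inhibitor. Compound 1 `Nc1nc(=O)ccn1COCCO` gives only a limit in this assay, > 400 ug/mL. Compound 2 `Nc1nc2c(nc(Br)n2COCCO)c(=O)[nH]1` gives 225 ug/mL in this assay. Compound 3 `Nc1nc2c(nc(I)n2COCCO)c(=O)[nH]1` gives in this assay only a limit, >= 250 ug/mL. Among the measured compounds shown here, compound 3 thus stands at a limit rather than at a number, and the one measured step in this assay, an at least 1.1-fold higher number from compound 2 to compound 3 (0.04 log units; that floor lies within the scatter), is within the scatter, so compound 2 and compound 3 cannot be told apart on these numbers. Compound 4 `CN(C)c1nc2c(=O)[nH]c(N)nc2n1COCCO` differs from compound 3 as follows: dimethylamino in place of iodo on an aromatic carbon. For the measured compounds named here, no measured step swaps iodo for dimethylamino; the only step in hand, an at least 1.1-fold higher number from compound 2 to compound 3 (0.04 log units; that floor lies within the scatter), concerns bromo to iodo and is within the scatter, which gives no direction for the present change. For compound 4 the expectation in this assay is no step beyond the scatter, and compound 4 is estimated at 300 ug/mL, between 150 ug/mL and 600 ug/mL. The step this estimate means, a step that the limit leaves unreadable from compound 3 to compound 4, is expected to stay within the scatter, with a fair chance that compound 4 again returns only a limit.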

Compound 4, concentration for 50% inhibition: > 400 ug/mL
Compound 4 gave a limit, no number; the forecaster's own chance of this, stated with the estimate: 60%; middle value at least 1.3-fold (0.12 log units) from the limit.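

In this assay compound 4 gives only a limit, > 400 ug/mL, so dimethylamino on this aromatic carbon between two ring nitrogen atoms yields no number, and of the three groups shown here only bromo, in compound 2, does. The one readable step is an at least 1.7-fold higher number from compound 2 to compound 4 (0.24 log units; that floor lies within the scatter), so on this floor alone, replacing bromo with dimethylamino is not shown to go beyond the scatter, though the limit does not fix the true size of the step. The step from compound 3 to compound 4 cannot be read, because neither value is a number: the limit of > 400 ug/mL in this assay, at which 2 of the 4 values shown sit.

On these data alone, how far the numbers of compound 3 and compound 4 lie past their limits remains open. Also open, as far as these compounds go, is whether a plain amino group or chloro on this carbon would give a number in this assay, and on which side of compound 2 it would fall.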